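The source may report more compounds than this note shows. Statements on the series, on what has been measured and on what is new or still open speak of the compounds shown alone.

Measured compounds:
compound 1 `O=C(Nn1c(-c2cccc([N+](=O)[O-])c2)nc2c(-c3ccc(Cl)cc3)n[nH]c2c1=O)c1ccccc1`, 88.6%
compound 2 `COc1cccc(-c2nc3c(-c4ccc(Cl)cc4)n[nH]c3c(=O)n2NC(=O)c2ccccc2)c1`, 81.8%
compound 3 `O=C(Nn1c(-c2cccc([N+](=O)[O-])c2)nc2c(-c3ccco3)n[nH]c2c1=O)c1ccccc1`, 18.7%

All three were tested in a functional assay on A549 cells (Homo sapiens) for cytotoxicity, read by sulforhodamine B assay, with a stated time of 2 days, tested at 100 uM; on this read-out higher numbers stand for more inhibition at the one concentration tested (going by the name of the read-out) and lower numbers for less inhibition. Compound 1 gives 88.6%, compound 2 gives 81.8%, and compound 3 gives 18.7%.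

Compound 1 and compound 2 differ in one place: methoxy in place of nitro on an aromatic carbon. This change made the step of a number 6.8 percentage points lower from compound 1 to compound 2 (within the scatter). Compound 4 `COc1cccc(-c2nc3c(-c4ccco4)n[nH]c3c(=O)n2NC(=O)c2ccccc2)c1` has not yet been measured; it comes from compound 3 by the same change in the same place: methoxy in place of nitro on an aromatic carbon. The cores of compound 1 and compound 3 differ as follows: furan-2-yl in place of 4-chlorophenyl on an aromatic carbon, and that difference made the step of a number 69.9 percentage points lower from compound 1 to compound 3 (beyond the scatter), so the same kind of change is now applied on a core that already gives a low number.

For compound 4 the expected step is a number 4.7 percentage points lower from compound 3 to compound 4 (within the scatter), small like the earlier one, since the matching step a number 6.8 percentage points lower from compound 1 to compound 2 (within the scatter) stayed within the scatter. Compound 4 is therefore estimated to give about 14%, most likely between 4% and 28%.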

Compound 4, a percentage reported as inhibition, at one concentration (the size of the read-out at that concentration, not a potency): 53.8%
Beside the measured number, compound 4's estimate is 39.8 percentage points below it; the whole stated range lies below it.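

On the core carrying furan-2-yl, methoxy in place of nitro gives a number 35.1 percentage points higher from compound 3 to compound 4 (beyond the scatter), so in this assay this change does not carry over unaltered from the core carrying 4-chlorophenyl: the same change on two cores in this assay, a number 6.8 percentage points lower (within the scatter) from compound 1 to compound 2 and a number 35.1 percentage points higher (beyond the scatter) from compound 3 to compound 4, 41.9 percentage points apart, beyond the scatter of two such steps. Read the other way, furan-2-yl in place of 4-chlorophenyl gives a number 28 percentage points lower from compound 2 to compound 4 (beyond the scatter), so the size of that change also depends on what sits at the other place: the same change on two cores in this assay, a number 69.9 percentage points lower (beyond the scatter) from compound 1 to compound 3 and a number 28 percentage points lower (beyond the scatter) from compound 2 to compound 4, 41.9 percentage points apart, beyond the scatter of two such steps. These four compounds show that the two places do not act independently on this read-out, but they do not explain why, they give inhibition at a single concentration rather than a potency, and one such comparison cannot predict how the change would behave on a further core.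

Going by these compounds, it remains open whether an amine or a carboxylic acid in place of nitro would behave like methoxy on each core. On these data alone, it is also open whether a longer chain in place of 4-chlorophenyl or furan-2-yl would show the same dependence.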